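The source may hold more compounds than are shown below. What is called first, only, known or untested is meant among the compounds shown, and "the series" means these compounds.

Compound 3 `COc1cccc(CNCCCNc2ccnc3cc(-c4ccc(F)cc4)ccc23)c1O` gives the highest number of the three measured in an ADME assay on HepG2 cells (Homo sapiens) for cytotoxicity, read by luminescence, CellTiter-Glo and ATP content, with a stated time of 72 h (a higher number here means that more compound is needed for the effect, a lower number that less compound is needed), namely 6840 nM; compound 2 `COc1cccc(CNCCCNc2ccnc3cc(Oc4ccccc4)ccc23)c1O` gives 6800 nM, and compound 1 `CCC(CC)c1ccc2c(NCCCNCc3cccc(OC)c3O)ccnc2c1` gives 410 nM. Compound 4 `COc1cccc(CNCCCNc2ccnc3cc(CC(C)C)ccc23)c1O` has not yet been measured; it differs from compound 3 by isobutyl in place of 4-fluorophenyl on an aromatic carbon. The step that bears most on this change is a 17-fold higher number from compound 1 to compound 3 (1.22 log units; beyond the scatter), where pentan-3-yl gave way to 4-fluorophenyl at the same carbon, while a 1.0-fold higher number from compound 2 to compound 3 (0.00 log units; within the scatter) shows the two aromatic substituents behaving alike. Because compound 1 gives 410 nM with pentan-3-yl at that carbon, compound 4 with isobutyl there is expected to move back toward it, a step of a 7.6-fold lower number from compound 3 to compound 4 (0.88 log units; beyond the scatter). Compound 4 is therefore estimated at 900 nM, within 300 nM to 3000 nM.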

Compound 4, half-maximal effective concentration: 2920 nM
The estimate for compound 4 lay 3.2-fold (0.51 log units) below the measured number; the range from low to high includes it.
By their numbers in this assay, from the lowest: compound 1; then compound 4; then compounds 2 and 3 (each within the scatter of the next).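

In this assay this carbon now separates two open-chain groups, and not only open-chain from aromatic substituents. Isobutyl stands apart from the aromatic substituents, with a 2.3-fold lower number from compound 3 to compound 4 (0.37 log units; beyond the scatter) and a 2.3-fold lower number from compound 2 to compound 4 (0.37 log units; beyond the scatter) and also from pentan-3-yl, with a 7.1-fold higher number from compound 1 to compound 4 (0.85 log units; beyond the scatter) so an open-chain group here does not by itself set the number. The larger part of the gap between compound 1 and compound 3 thus lies between pentan-3-yl and isobutyl.

On these data alone, whether an amine, a carboxylic acid or a longer chain at this carbon would fall nearer compound 1 or compound 3 stays open. Nothing available gives a cause for these steps.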